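Hydroxybenzyl Ether Replaces Dinitrophenyl on a Thiophene Sulfonamide Series

This account rests on a few compounds, and the source may have more. Where it says the series, first, only, none or still open, it means among the compounds named here.

In a functional assay on RS4-11 cells (Homo sapiens) for inhibition, read by CCK-8 assay, with a stated time of 48 h (on this read-out lower numbers stand for stronger inhibition and higher numbers for weaker inhibition), compound 2 `O=C(NCCNS(=O)(=O)c1ccc(-c2ccccc2Oc2ccc([N+](=O)[O-])c([N+](=O)[O-])c2)s1)Nc1cc(C(F)(F)F)cc(C(F)(F)F)c1` gives 2400 nM. Compound 3 `O=[N+]([O-])c1ccc(NC(=S)NCCNS(=O)(=O)c2ccc(-c3ccccc3O[C@H]3CC[C@H](O)CC3)s2)cc1` gives 1500 nM in this assay, so compound 2 holds the higher of the two numbers, yet the gap to compound 3 sits within the usual scatter, and neither can be set apart from the other. Compound 1 `COc1ccc(Oc2ccccc2-c2ccsc2S(=O)(=O)N2CCN(C(=S)Nc3cc(C(F)(F)F)cc(C(F)(F)F)c3)CC2)cc1OC` reaches only a limit of this assay, > 50000 nM, and no number is known for it (the limit of > 50000 nM in this assay, at which 1 of the 3 values shown sits).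

Compound 4 `O=C(NCCNS(=O)(=O)c1ccc(-c2ccccc2OCc2cccc(O)c2)s1)Nc1cc(C(F)(F)F)cc(C(F)(F)F)c1` differs from compound 2 in one place: 3-hydroxybenzyl in place of 3,4-dinitrophenyl on an oxygen on an aromatic ring. Going by the values given here, no measured pair shows this change, so the expected step from compound 2 to compound 4 is set at a 1.2-fold lower number from compound 2 to compound 4 (0.08 log units; within the scatter), a drift within the scatter rather than a directed shift. Compound 4 is therefore estimated at 2000 nM, with a range from 600 nM to 7000 nM.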

Compound 4, half-maximal inhibitory concentration: 3000 nM
For compound 4 the middle estimate is 1.5-fold (0.18 log units) below the measured one; low and high end bracket the measured number.
By their numbers in this assay, from the lowest: compounds 3, 2 and 4 (each within the scatter of the next). At a limit, above all of these: compound 1.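

In this assay, the step of a 1.3-fold higher number from compound 2 to compound 4 (0.10 log units; within the scatter) shows that 3-hydroxybenzyl can stand in place of 3,4-dinitrophenyl on this oxygen on an aromatic ring with no shift that can be told from the scatter. Within this pair, then, the value does not depend on keeping 3,4-dinitrophenyl at this place. As far as these compounds go, whether an amine or a carboxylic acid in place of the hydroxyl on the benzyl group would give a number beyond the scatter of compound 4 stays open. No measurement given here bears on the reason for this result.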